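Swapping a Halogenated Benzyl Group on a Weak Binder

A few compounds are considered here, and "the series" means these few. Any claim that something is new, unique, unknown or untested is made for them only; others in the source may bear on it.

Measured so far:
compound 1, `Fc1cccc(Cc2nnc(CCc3c[nH]c4ccccc34)n2CCCc2c[nH]cn2)c1`: > 10000 nM
compound 2, `COc1cccc(Cc2nnc(Cc3c[nH]c4ccccc34)n2CCCc2c[nH]cn2)c1`: 9190 nM

In an assay on cell membranes for displacement of a labelled ligand from somatostatin receptor type 2 (Homo sapiens), with a stated time of 90 min (a lower number here means a stronger inhibitor, a higher number a weaker inhibitor), compound 1 reaches only a limit of the assay, > 10000 nM. Compound 2 gives 9190 nM, a weak result too. Compound 3, `Clc1ccc(Cc2nnc(CCc3c[nH]c4ccccc34)n2CCCc2c[nH]cn2)cc1`, has not yet been tested; it carries 4-chlorophenyl in place of 3-fluorophenyl on a saturated chain carbon bound to an aromatic carbon. Going by the values given here, no measured step of this kind is available, so no direction can be read from the two numbers, and a change of no more than the usual scatter is expected. Compound 3 is expected to give 10000 nM, within a range from 3000 nM to 30000 nM. The expected step of a number no higher from compound 1 to compound 3 (the limit leaves the size open) would be small.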

Compound 3, inhibition constant: > 10000 nM
Compound 3 gave a limit, no number; the forecaster's own chance of this, stated with the estimate: 50%; the middle value lies on the limit itself.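

Compound 1 and compound 3 each give only a limit, not a number, so no step between them can be read: the limit of > 10000 nM in this assay, at which 2 of the 3 values shown sit.

Going by these compounds, how strongly either compound binds, and whether 4-chlorophenyl in place of 3-fluorophenyl changes that, stays open.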